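The source may hold more compounds than are shown below. What is called first, only, known or untested is meant among the compounds shown, and "the series" means these compounds.

Compound 2 `N=C(N/C(=N/O)c1nonc1N)c1ccccc1` sits at the bottom of the three numbers measured in an assay on isolated protein for antagonist activity at RAC-alpha serine/threonine-protein kinase (Homo sapiens), read by surface plasmon resonance, with a stated time of 30 min, tested at 50 uM; on this read-out lower numbers stand for less inhibition and higher numbers for more inhibition at the one concentration tested (going by the name of the read-out): compound 2 gives 54%. Its two neighbours differ from it only on the aromatic carbon that carries hydrogen in compound 2. Compound 1 `N=C(N/C(=N/O)c1nonc1N)c1ccccc1N` carries an amino group there and gives 74% in this assay, so the move from amino to hydrogen is a number 20 percentage points lower from compound 1 to compound 2 (beyond the scatter). Compound 3 `N=C(N/C(=N/O)c1nonc1N)c1ccccc1Br` carries bromo there and gives 80%, and the move from hydrogen to bromo is a number 26 percentage points higher from compound 2 to compound 3 (beyond the scatter). Compound 4 `N=C(N)NC(=N)N/C(=N/O)c1nonc1N` goes further than either: a group of 4 heavy atoms (1 carbon, 3 nitrogen; no ring) in place of a group of 6 heavy atoms (6 carbon; one six-membered aromatic ring of carbon only), on a carbon with a double bond to nitrogen. Going by the values given here, no measured step touches the phenyl itself; the two steps that exist, both modest and both beyond the scatter, only exchange the substituent on that ring, so they bear on compound 4 indirectly. They do show that this part of the molecule moves the number, and taking the whole ring away is a larger change than either. The step from compound 2 to compound 4 in this assay is therefore expected to be downward, a number 19 percentage points lower from compound 2 to compound 4 (beyond the scatter), with wide uncertainty. Compound 4 is estimated at 35%, somewhere between 5% and 65%.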

Compound 4, a percentage reported as inhibition, at one concentration (the size of the read-out at that concentration, not a potency): 95%
Compound 4: the middle estimate sits 60 percentage points below what was measured, outside the stated range (above it).
By their numbers in this assay, from the lowest: compound 2; then compounds 1 and 3 (each within the scatter of the next); then compound 4.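

Taking the phenyl away altogether, and putting the group of 4 heavy atoms (1 carbon, 3 nitrogen; no ring) on the carbon with a double bond to nitrogen, gives a number 41 percentage points higher from compound 2 to compound 4 (beyond the scatter) in this assay. The earlier steps shown here only exchanged a substituent on the phenyl, so they could not show that a six-membered aromatic ring of carbon is dispensable at this place for a high number; here the open group carries the number past those of all three earlier compounds. The change swaps a group with no hydrogen-bond donors for one with 3, and adds nitrogen in place of an all-carbon ring, but nothing at hand says which of these differences accounts for the step.

The compounds shown leave open whether the ring's absence or the particular nitrogen-rich group matters, which a cyclohexyl ring, a plain amine or a short alkyl chain at the same carbon would begin to separate. These are also readings at a single concentration, so they leave open how far compound 2 and compound 4 differ in potency.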